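This account rests on a few compounds, and the source may have more. Where it says the series, first, only, none or still open, it means among the compounds named here.

Measured compounds so far:

- compound 1, `CC(C)CCN1C(=O)C(C2=CS(=O)(=O)c3cc(NS(C)(=O)=O)ccc3N2)=C(O)[C@@H]1C(C)(C)C`. In an ADME assay on 2209-23 cells (Homo sapiens) for cytotoxicity, read by WST assay and thymidine incorporation (on this read-out higher numbers stand for lower toxicity in this test and lower numbers for higher toxicity in this test), compound 1 gives > 50000 nM, which is a limit of the assay and not a number.
- compound 2, `CC(C)(C)[C@H]1C(O)=C(C2=C(C(N)=O)S(=O)(=O)c3cc(NS(C)(=O)=O)ccc3N2)C(=O)N1Cc1ccc(F)cc1`. In this assay compound 2 gives > 50000 nM, again a limit.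
- compound 3, `CC(C)(C)[C@H]1C(O)=C(C2=CS(=O)(=O)c3cc(NS(C)(=O)=O)cc(F)c3N2)C(=O)N1Cc1ccc(F)cc1`. In this assay compound 3 gives > 50000 nM, also a limit.

Compound 3 therefore stands nowhere that can be ranked: its value is a limit, and the two further values shown are limits as well, so all three sit together at the limit of > 50000 nM in this assay, at which 3 of the 3 values shown sit. Going by the values given here, no pair of measured compounds differs in a single place, and no measured step is available to calibrate the change now in hand.

Compound 4, `CC(C)(C)[C@H]1C(O)=C(C2=CS(=O)(=O)c3cc(NS(C)(=O)=O)ccc3N2)C(=O)N1Cc1ccc(F)cc1`, has not yet been measured in this assay. Against compound 3 the difference is hydrogen in place of fluoro on an aromatic carbon.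

With every measured value at the same limit, the expected step of a number no higher from compound 3 to compound 4 (the limit leaves the size open) in this assay is none beyond the usual scatter. Compound 4 is expected to give about 50000 nM in this assay, within the range 25000 nM to 100000 nM, and most probably to be reported once more as a limit rather than a number.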

Compound 4, half-maximal cytotoxic concentration: > 50000 nM
Compound 4 was reported as a limit; the forecaster's own chance of this, stated with the estimate: 85%; the middle value lies on the limit itself.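

In this assay compound 4 gives > 50000 nM, a limit of the assay and not a number. No step to compound 4 from compound 1, compound 2 or compound 3 can be read, as all four sit together: the limit of > 50000 nM in this assay, at which 4 of the 4 values shown sit.

The compounds shown leave open whether any of these three structural changes alters cytotoxicity.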